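Cyclopentyl Amide in Place of a Fluoroethyl Carbamate

The compounds below may be only part of what the source reports. "The series", "measured", "known", "first", "only" and "open" are said of these compounds alone.

Compound 1 `Cc1nc(S(C)(=O)=O)ccc1Oc1ncnc(OC2CCN(C(=O)OC(C)F)CC2)c1F`: 315 nM
Compound 2 `Cc1nc(S(C)(=O)=O)ccc1Oc1ncnc(OC2CCN(C(=O)SC(C)C)CC2)c1F`: 41.3 nM
Compound 3 `Cc1nc(S(C)(=O)=O)ccc1Oc1ncnc(OC2CCN(C(=S)OC3(C)CC3)CC2)c1F`: 48.8 nM

In a functional assay on isolated protein for inhibition of Glucose-dependent insulinotropic receptor (Rattus norvegicus), read by HTRF and cAMP accumulation (on this read-out lower numbers stand for an effect already at smaller amounts and higher numbers for an effect only at larger amounts of compound), compound 1 stands highest of the three measured compounds. The two measured steps that leave compound 1 both lower the number: a 7.6-fold lower number from compound 1 to compound 2 (0.88 log units; beyond the scatter) and a 6.5-fold lower number from compound 1 to compound 3 (0.81 log units; beyond the scatter). Both take place at the same end of the shared core, on or next to the carbonyl that sits on the amide-type nitrogen in the ring.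

Compound 4 `Cc1nc(S(C)(=O)=O)ccc1Oc1ncnc(OC2CCN(C(=O)C3CCCC3)CC2)c1F` differs from compound 1 in the same region: a group of 5 heavy atoms (5 carbon; one five-membered non-aromatic ring of carbon only) in place of a group of 4 heavy atoms (2 carbon, 1 oxygen, 1 fluorine; no ring), on a carbonyl carbon. Since the steps to compound 2 and compound 3 both fell beyond the scatter in the same direction, a modest step lower is expected here too, a 5.7-fold lower number from compound 1 to compound 4 (0.76 log units; beyond the scatter). Compound 4 is therefore estimated at 55 nM, with a range from 20 nM to 160 nM.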

Compound 4, half-maximal effective concentration: 407 nM
Beside the measured number, compound 4's estimate is 7.4-fold (0.87 log units) below it, and the stated range ends below it.
By their numbers in this assay, from the lowest: compounds 2 and 3 (each within the scatter of the next); then compounds 1 and 4 (each within the scatter of the next).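

In this assay, cyclopentyl on the carbonyl carbon gives a 1.3-fold higher number from compound 1 to compound 4 (0.11 log units; within the scatter), without the drop seen with compounds 2 and 3. The sulfur-containing compounds remain clearly apart from it, with an 8.3-fold higher number from compound 3 to compound 4 (0.92 log units; beyond the scatter) and a 9.9-fold higher number from compound 2 to compound 4 (0.99 log units; beyond the scatter), so a lower number at this end depends on which group is present, and not every replacement of the fluoroethyl carbamate gives one. No evidence on the cause is available.

As far as these compounds go, it remains open whether an isopropyl or a piperidine on the same carbonyl carbon would behave like cyclopentyl, and whether the sulfur in compounds 2 and 3 is what sets them apart.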